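A Single Fluoro Swap in a Cell Toxicity Test

The compounds below may be only part of what the source reports. "The series", "measured", "known", "first", "only" and "open" are said of these compounds alone.

Going by the values given here, two related compounds have numbers so far. In a functional assay on Huh-5-2 cells (Homo sapiens) for cytotoxicity, read by MTT assay (on this read-out higher numbers stand for lower toxicity in this test and lower numbers for higher toxicity in this test), compound 1 `Cc1ccc(C(Oc2ccc(-c3nc4cc(C(=O)O)ccc4n3C3CCCCC3)cc2)c2ccc(C)cc2)cc1` gives 23500 nM, and compound 2 `O=C(O)c1ccc2c(c1)nc(-c1ccc(OC(c3ccc(F)cc3)c3ccc(F)cc3)cc1)n2C1CCCCC1` gives 27700 nM. These two values lie within the usual scatter of repeated measurements, so compound 2 stands level with compound 1 and neither can be ranked ahead of the other.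

The next molecule, compound 3 `O=C(O)c1ccc2c(c1)nc(-c1ccc(OC(c3ccc(F)cc3)c3ccc(F)cc3)cc1F)n2C1CCCCC1`, is compound 2 with a single change: fluoro in place of hydrogen on an aromatic carbon. A fluoro takes the place of hydrogen on an aromatic carbon, ortho to a large group and meta to a large group. Among the compounds with values here, no measured pair yet isolates a swap of this kind, so the data offer no direct guide to its effect. The change is small, so no shift beyond the scatter is expected in this assay. The estimated step is a 1.1-fold lower number from compound 2 to compound 3 (0.03 log units; within the scatter), and it is expected to stay within the scatter. Compound 3 is estimated at 26000 nM, with an expected range from 14000 nM to 45000 nM.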

Compound 3, half-maximal cytotoxic concentration: 27200 nM
Compound 3: the middle estimate sits 1.0-fold (0.02 log units) below what was measured; low and high end bracket the measured number.
By their numbers in this assay, from the lowest: compounds 1, 3 and 2 (each within the scatter of the next).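

In this assay the swap of hydrogen for fluoro gives a 1.0-fold lower number from compound 2 to compound 3 (0.01 log units; within the scatter) and so leaves the two compounds level. Going by these compounds alone, this is the first pair in the set that differs in only one place, which makes it the first direct reading of a change at this aromatic carbon, ortho to a large group and meta to a large group. For this one swap at this one carbon, the number stays where compound 2 put it, and nothing measured here explains that result.

Going by these compounds, a single atom at a single carbon says little about the rest of this ring, so it remains open whether fluoro on another of its carbons would also leave the number level. On these data alone, it is equally open whether a chlorine atom, a methoxy group or an amine on the same carbon would stay within the scatter of compound 2 or move the number beyond it, in either direction.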